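The source may hold more compounds than are shown below. What is called first, only, known or untested is meant among the compounds shown, and "the series" means these compounds.

Measured compounds:
compound 1 `O=C(Nc1ccc(OC(F)(F)F)cc1)NC1CCN(C(=O)C2CCCOC2)CC1` — 868 ug/mL
compound 2 `O=C(Nc1ccc(OC(F)(F)F)c(F)c1)NC1CCN(C(=O)N2CCOCC2)CC1` — 294 ug/mL
compound 3 `O=C(Nc1ccc(C(F)(F)F)cc1)NC1CCN(C(=O)C2CCCOC2)CC1` — 25 ug/mL

In a physicochemical assay for solubility, read by mass spectrometry, in phosphate buffer, with a stated time of 24 h, at pH 3 (on this read-out higher numbers stand for higher solubility and lower numbers for lower solubility), compound 1 stands highest of the three numbers; compound 2 gives 294 ug/mL, a lower number beyond the scatter, and compound 3 gives 25 ug/mL, the lowest. Going by the values given here, the only measured single-place step, a 35-fold lower number from compound 1 to compound 3 (1.54 log units; beyond the scatter), concerns the group on the aromatic ring, not the ring attached to the carbonyl. Compound 4 `O=C(Nc1ccc(OC(F)(F)F)cc1)NC1CCN(C(=O)C2CCOC2)CC1` differs from compound 1 in one place: oxolan-3-yl in place of oxan-3-yl on a carbonyl carbon. Among the compounds with values here, no measured pair changes this ring, and compound 2 differs from compound 1 in two places, so no measured step bears directly on the change. A step of a 1.1-fold higher number from compound 1 to compound 4 (0.04 log units; within the scatter) is therefore expected, within the scatter. Compound 4 is expected to give 950 ug/mL, with a range from 450 ug/mL to 2000 ug/mL.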

Compound 4, solubility: 91 ug/mL
Compound 4: the middle estimate sits 10-fold (1.02 log units) above what was measured; measured number below the stated range.
By their numbers in this assay, from the lowest: compound 3; then compound 4; then compound 2; then compound 1.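

In this assay, oxolan-3-yl in place of oxan-3-yl on a carbonyl carbon gives a 9.5-fold lower number from compound 1 to compound 4 (0.98 log units; beyond the scatter), so this position, and not only the group on the aromatic ring, can shift the number beyond the scatter. The change is a small one: both groups are non-aromatic rings with one hetero atom and no net charge, differing in ring size. Nothing measured here accounts for the step.

As far as these compounds go, it remains open how oxan-4-yl or cyclohexyl, which has no ring oxygen, would read at this carbonyl carbon. Whether the same ring change would give a similar step alongside trifluoromethyl on the aromatic ring is also unknown.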